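From 3-Hydroxyphenyl to 4-Hydroxyphenyl on an Amide-Type Nitrogen

The source may hold more compounds than are shown below. What is called first, only, known or untested is meant among the compounds shown, and "the series" means these compounds.

In a functional assay on MOLT-4 cells (Homo sapiens) for inhibition, read by MTT assay, with a stated time of 72 h (on this read-out lower numbers stand for stronger inhibition and higher numbers for weaker inhibition), compound 3 `COc1cc(NC(C)CCCNC(=O)Nc2cccc(O)c2)c2ncccc2c1` gives 24000 nM, within the scatter of compound 1 `COc1cc(NC(C)CCCNC(=O)Nc2cccc(F)c2)c2ncccc2c1` at 23000 nM, while compound 2 `COc1cc(NC(C)CCCNC(=O)NNC(=O)Nc2ccc(Cl)cc2)c2ncccc2c1` reads higher at 186000 nM. Compound 4 `COc1cc(NC(C)CCCNC(=O)Nc2ccc(O)cc2)c2ncccc2c1` has 4-hydroxyphenyl in place of 3-hydroxyphenyl on an amide-type nitrogen. For the measured compounds named here, no measured step makes this exact change. The closest evidence is a 1.0-fold higher number from compound 1 to compound 3 (0.02 log units; within the scatter), where hydroxy replaces fluoro on an aromatic carbon and the size stays within the scatter. The larger 7.8-fold lower number from compound 2 to compound 3 (0.89 log units; beyond the scatter) exchanges a much different group, so it bears less on this case. No step beyond the scatter is therefore expected, and no direction is favoured. The expected step is a 1.0-fold higher number from compound 3 to compound 4 (0.02 log units; within the scatter). Compound 4 is estimated at 25000 nM, with an expected range of 12000 nM to 52000 nM.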

Compound 4, half-maximal inhibitory concentration: 21000 nM
Compound 4: the middle estimate sits 1.2-fold (0.08 log units) above what was measured; the measured number falls inside the stated range.
By their numbers in this assay, from the lowest: compounds 4, 1 and 3 (each within the scatter of the next); then compound 2.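

In this assay, the 4-hydroxyphenyl and 3-hydroxyphenyl groups on the amide-type nitrogen read alike within the scatter (a 1.1-fold lower number from compound 3 to compound 4 (0.06 log units; within the scatter)), and 4-hydroxyphenyl also matches 3-fluorophenyl (a 1.1-fold lower number from compound 1 to compound 4 (0.04 log units; within the scatter)). The gap to the ((4-chlorophenyl)carbamoyl)amino group stays beyond the scatter (an 8.9-fold lower number from compound 2 to compound 4 (0.95 log units; beyond the scatter)), so compound 1, compound 3 and compound 4 together stand apart from compound 2. No measurement shown here accounts for these readings.

From the compounds shown here alone, whether an amine or a carboxylic acid in place of the hydroxy would read differently stays open, as does the effect of a longer chain.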